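The source may hold more compounds than are shown below. What is called first, only, known or untested is meant among the compounds shown, and "the series" means these compounds.

In a functional assay on HCT-116 cells (Homo sapiens) for cytotoxicity, read by sulforhodamine B assay, with a stated time of 48 h (a higher number here means a weaker inhibitor, a lower number a stronger inhibitor), compound 1 `O=C(Nc1n[nH]c2c1CN(C(=O)c1ccccc1)C2)c1ccccc1` gives 6400 nM, compound 2 `O=C(Nc1n[nH]c2c1CN(C(=O)c1ccccc1)C2)c1ccc(F)cc1` gives 3190 nM and compound 3 `CC(=O)n1nc(NC(=O)c2ccccc2)c2c1CN(C(=O)c1ccccc1)C2` gives 580 nM. Compound 3 therefore has the lowest number of the three and is the strongest inhibitor measured so far. Compound 4 `CC(C)C(=O)n1nc(NC(=O)c2ccccc2)c2c1CN(C(=O)c1ccccc1)C2` has not yet been measured. It differs from compound 3 in one place: isopropyl in place of methyl on a carbonyl carbon.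

The most relevant measured change is acetyl in place of hydrogen on an aromatic nitrogen, which gave an 11-fold lower number from compound 1 to compound 3 (1.04 log units; beyond the scatter). Compound 4 keeps that carbonyl on the aromatic nitrogen, so it is expected to keep most of this large gain. The other measured change, fluoro in place of hydrogen on an aromatic carbon, gave a 2.0-fold lower number from compound 1 to compound 2 (0.30 log units; within the scatter) and says little about this swap. For the measured compounds named here, no measured pair varies the group on this carbonyl, so the expectation is uncertain. The estimated change is a 1.0-fold higher number from compound 3 to compound 4 (0.01 log units; within the scatter), and no step beyond the scatter is expected in either direction. For compound 4, the expected value is 600 nM, with an estimated range from 200 nM to 1800 nM.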

Compound 4, half-maximal inhibitory concentration: 2020 nM
Compound 4: middle estimate off by 3.4-fold (0.53 log units), on the low side; the whole stated range lies below it.
By their numbers in this assay, from the lowest: compound 3; then compounds 4, 2 and 1 (each within the scatter of the next, the first and the last beyond it).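

In this assay, for the compounds shown here, the earlier compounds showed only that putting an acetyl on the aromatic nitrogen lowers the number, but isopropyl in place of methyl on the carbonyl carbon now brings a 3.5-fold higher number from compound 3 to compound 4 (0.54 log units; beyond the scatter), so the group on this carbonyl matters as well. The carbonyl on the nitrogen still helps with isopropyl in place, with isopropylcarbonyl giving a 3.2-fold lower number from compound 1 to compound 4 (0.50 log units; beyond the scatter), although this gain is smaller than an 11-fold lower number from compound 1 to compound 3 (1.04 log units; beyond the scatter) seen with acetyl. Nothing given here explains why the larger group does less well.

With only methyl and isopropyl on this carbonyl, two points cannot show a trend. From the compounds shown here alone, an ethyl group, a longer chain such as butyl, a cyclopropyl ring or an amine at this place remains open, as does the effect of the acetyl on the fluoro compound 2.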